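Ring-nitrogen substituent swap in the amide series: exposure notes

The source may hold more compounds than are shown below. What is called first, only, known or untested is meant among the compounds shown, and "the series" means these compounds.

Compound 1 `CC(C)(O)c1ccc(-c2cnc3c(n2)N(CC2CCOCC2)C(=O)CN3)cn1` in an ADME assay on the whole organism for pharmacokinetics, with Rattus norvegicus as the target, at a dose of 5 mg/kg by the oral route (on this read-out lower numbers stand for lower exposure and higher numbers for higher exposure at the dose given), gives 1600 nM, the second highest of three numbers. Compound 3 `CC(C)(O)c1ccc(-c2cnc3c(n2)N(CCC2CCOCC2)C(=O)CN3)cn1` gives 1700 nM; the step of a 1.1-fold higher number from compound 1 to compound 3 (0.03 log units; within the scatter) lies within the scatter. Within the data shown here, compound 2 `CO[C@H]1CC[C@H](CN2CC(=O)Nc3ncc(-c4ccc(C(C)(C)O)nc4)nc32)CC1` gives 700 nM, which is lower than compound 1 beyond the scatter, though no single-site step joins these two. Compound 4 `CO[C@H]1CC[C@H](N2C(=O)CNc3ncc(-c4ccc(C(C)(C)O)nc4)nc32)CC1` differs from compound 1 by 4-methoxycyclohexyl in place of (oxan-4-yl)methyl on an amide-type nitrogen in a ring. Among the measured compounds shown here, the only measured step bearing on it, compound 1 to compound 3, is within the scatter. The ring that enters in compound 4 is the ring already carried by compound 2, whose number of 700 nM is the lower one. A modest drop is therefore expected, a 1.8-fold lower number from compound 1 to compound 4 (0.25 log units; within the scatter). The value of compound 4 is estimated at 900 nM, with a range from 400 nM to 2000 nM.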

Compound 4, maximal plasma concentration: 2900 nM
Compound 4: the middle estimate sits 3.2-fold (0.51 log units) below what was measured, outside the stated range (above it).
By their numbers in this assay, from the lowest: compound 2; then compounds 1, 3 and 4 (each within the scatter of the next).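

In this assay, 4-methoxycyclohexyl on the amide-type nitrogen in a ring gives a 1.8-fold higher number from compound 1 to compound 4 (0.26 log units; within the scatter) and a 1.7-fold higher number from compound 3 to compound 4 (0.23 log units; within the scatter), so this carbon-only ring is not separated from either oxane-bearing group. The ring alone also does not fix a low number: compound 2 gives 700 nM, while compound 4, with the same ring, gives 2900 nM. Nothing available explains these numbers.

Open, going by these compounds, is how an amine or a carboxylic acid in place of the methoxy group on the cyclohexyl ring would read in this assay.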